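The compounds below may be only part of what the source reports. "The series", "measured", "known", "first", "only" and "open" are said of these compounds alone.

Measured in a functional assay on HeLa cells (Homo sapiens) for antiproliferative activity, read by MTT assay, with a stated time of 72 h; on this read-out higher numbers stand for weaker inhibition and lower numbers for stronger inhibition:
- compound 1 `O=C1C[C@H]2O[C@H](Cc3ccccc3)[C@H](OCc3ccccc3)[C@H]2O1`: 4320 nM
- compound 2 `O=C1C[C@H]2O[C@H](Cc3ccccc3)[C@H](O)[C@H]2O1`: 4420 nM

Compound 2 stands within the scatter of compound 1, so the two cannot be ranked on these numbers. Compound 3 `Cc1ccccc1[C@H](c1ccccc1)[C@H]1O[C@@H]2CC(=O)O[C@@H]2[C@H]1O` keeps the free hydroxyl of compound 2 and differs as follows: 2-methylphenyl in place of hydrogen on a saturated chain carbon bound to an aromatic carbon and a saturated ring carbon. That is, 2-methylphenyl in place of hydrogen on a saturated chain carbon bound to an aromatic carbon and a saturated ring carbon.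

Within the data shown here, the only measured step, a 1.0-fold higher number from compound 1 to compound 2 (0.01 log units; within the scatter), lies within the scatter and concerns a group on an oxygen, not this carbon. Among the measured compounds shown here, it bears only weakly on the new change, and no measured compound carries a substituent at this place. The data support no clear direction. The expected change is small and uncertain: a 1.5-fold lower number from compound 2 to compound 3 (0.17 log units; within the scatter). In this assay the estimate for compound 3 is 3000 nM, with an expected range from 600 nM to 12000 nM.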

Compound 3, half-maximal inhibitory concentration: 11400 nM
For compound 3 the middle estimate is 3.8-fold (0.58 log units) below the measured one, within the range that was stated.
By their numbers in this assay, from the lowest: compounds 1 and 2 (each within the scatter of the next); then compound 3.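

In this assay, among these compounds, the entry of 2-methylphenyl in place of hydrogen on this saturated chain carbon gives a 2.6-fold higher number from compound 2 to compound 3 (0.41 log units; beyond the scatter) and so marks the first change that lies beyond the scatter. This carbon therefore responds to substitution, whereas the change on the oxygen did not, and here the added group goes with weaker inhibition. The step is modest and rests on one pair of compounds, and no measurement at hand accounts for it.

Going by these compounds, whether a smaller group on this carbon, such as methyl, or a group carrying an amine or a carboxylic acid would move the number in the same direction remains open. Also open, on these data alone, is whether the methyl of the 2-methylphenyl group has any part in the step, or whether the aromatic ring alone would give the same result.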